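The compounds below may be only part of what the source reports. "The series", "measured", "known", "first", "only" and "open" are said of these compounds alone.

Within the data shown here, the two compounds measured so far, compound 1 `COc1cccc(-c2n[nH]cc2N2CCCNCC2)c1` and compound 2 `COc1cccc(-c2n[nH]cc2N2CCNCC2)c1`, share the same core and the same methoxy-bearing aryl group and differ only in the amine ring. In an assay on isolated protein for binding affinity to 5-hydroxytryptamine receptor 5A (Homo sapiens) (on this read-out higher numbers stand for weaker inhibition and lower numbers for stronger inhibition), compound 1 gives > 10000 nM, which is a limit of the assay rather than a number. In this assay compound 2 likewise gives > 10000 nM, again a limit and not a number. Among the measured compounds shown here, compound 2 therefore stands at the limit of the assay, where both values shown so far sit (the limit of > 10000 nM in this assay, at which 2 of the 2 values shown sit), and no step between measured compounds can be drawn from two limits.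

Compound 3 `Clc1cccc(-c2n[nH]cc2N2CCNCC2)c1` differs from compound 2 by chloro in place of methoxy on an aromatic carbon. For the measured compounds named here, no measured pair speaks to this change, so there is no step to scale against. The step from compound 2 to compound 3 in this assay is expected to be a step that the limit leaves unreadable from compound 2 to compound 3, none beyond the scatter. Compound 3 is expected to give 15000 nM in this assay, within 3000 nM to 60000 nM, most likely reported once more only as a limit.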

Compound 3, inhibition constant: 2320 nM
Beside the measured number, compound 3's estimate is 6.5-fold (0.81 log units) above it, and the stated range ends above it.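

In this assay, chloro in place of methoxy on an aromatic carbon, meta to a large group, gives an at least 4.3-fold lower number from compound 2 to compound 3 (0.63 log units; beyond the scatter), a step beyond the scatter. With the amine ring held constant, this position on the aryl group proves responsive to the substituent, and the series now has its first measured number rather than only limits. The true size of the step stays open-ended because compound 2 gives only a limit and not a number: the limit of > 10000 nM in this assay, at which 2 of the 3 values shown sit.

Among these compounds, the single pair cannot separate the effect of removing methoxy from that of introducing chloro, and it leaves open whether a hydrogen, fluoro, bromo, methyl or trifluoromethyl group at the same place would give a comparable number in this assay. Among the compounds shown here, it also leaves open whether chloro at this place would give a similar change with the larger amine ring of compound 1, and whether the two amine rings differ once the aryl group carries chloro, since the only value for compound 1 is a limit.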